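The source may report more compounds than this note shows. Statements on the series, on what has been measured and on what is new or still open speak of the compounds shown alone.

Measured in a functional assay on K562 cells (Homo sapiens) for antiproliferative activity, read by MTT assay, with a stated time of 72 h; on this read-out lower numbers stand for stronger inhibition and higher numbers for weaker inhibition:
- Compound 1 `COc1cc(-n2ncnc2-c2ccc(C)cc2)cc(OC)c1OC`: > 10000 nM (a limit)
- Compound 2 `COc1ccc(-c2ncnn2-c2cc(OC)c(OC)c(OC)c2)cc1`: 950 nM
- Compound 3 `COc1cc(-n2ncnc2-c2ccc(Cl)cc2)cc(OC)c1OC`: > 10000 nM (a limit)

Compound 3 gives no number in this assay and stands only at a limit, which is the limit of > 10000 nM in this assay, at which 2 of the 3 values shown sit. Compound 4 `COc1cccc(-c2ncnn2-c2cc(OC)c(OC)c(OC)c2)c1` carries 3-methoxyphenyl in place of 4-chlorophenyl on an aromatic carbon of the shared core: 3-methoxyphenyl in place of 4-chlorophenyl on an aromatic carbon.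

The measured steps that bear on this change all concern the same aromatic ring. Methoxy in place of methyl gave an at least 10-fold lower number from compound 1 to compound 2 (1.02 log units; beyond the scatter), and chloro in place of methoxy gave an at least 10-fold higher number from compound 2 to compound 3 (1.02 log units; beyond the scatter). Both steps are large. Chloro in place of methyl gave a step that the two limits leave unreadable from compound 1 to compound 3, so that pair says little. Among these compounds, only the methoxy compound gives a number, and compound 4 also carries a methoxy group, so a lower number than that of compound 3 is expected. However, no measured compound carries the 3-methoxyphenyl group itself, so the gain seen with compound 2 at 950 nM may carry over only in part.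

The expected change is an at least 3.3-fold lower number from compound 3 to compound 4 (0.52 log units; beyond the scatter). For compound 4 the estimate is 3000 nM, with an expected range from 600 nM to 10000 nM.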

Compound 4, half-maximal inhibitory concentration: > 10000 nM
Compound 4 gave a limit, no number; the forecaster's own chance of this, stated with the estimate: 35%; at least 3.3-fold (0.52 log units) between middle value and limit.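

In this assay, the result shows that a methoxy group on the phenyl ring does not by itself bring the activity of compound 2: 3-methoxyphenyl in place of 4-methoxyphenyl gave an at least 10-fold higher number from compound 2 to compound 4 (1.02 log units; beyond the scatter). At this place on the shared core, it therefore matters where the methoxy group sits on the phenyl ring, not only that it is present, and among the compounds shown only the 4-methoxyphenyl group gives a number. Compound 4 gives only a limit, as compounds 1 and 3 do, so its steps to those two compounds cannot be read: the limit of > 10000 nM in this assay, at which 3 of the 4 values shown sit.

On these data alone, how far compounds 1, 3 and 4 lie past that limit stays open, and so does any order among them, including whether 3-methoxyphenyl differs at all from 4-chlorophenyl or 4-methylphenyl. Also open, as far as these compounds go, is whether another group in place of the methoxy group of compound 2, such as an ethoxy group, a hydroxy group or an amine, would keep a measurable number in this assay.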